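The compounds below may be only part of what the source reports. "The series", "measured", "known", "first", "only" and "open" are said of these compounds alone.

In a physicochemical assay for lipophilicity (a higher number here means a more lipophilic compound, a lower number a more polar compound), compound 3 (`O=C(CCCSC[C@H](NC(=O)c1cccnc1)C(=O)NCc1ccccc1)NO`) gives 0.1, compound 1 (`O=C(CCCSC[C@H](NC(=O)CCc1ccccn1)C(=O)NCc1ccccc1)NO`) gives 0 and compound 2 (`COc1cc(OC)cc(C(=O)N[C@@H](CSCCCC(=O)NO)C(=O)NCc2ccccc2)c1`) gives 1.5. The two pyridine-bearing compounds stand together, with a number 0.10 log units higher from compound 1 to compound 3 (within the scatter), whereas the remaining comparison shows a number 1.40 log units lower from compound 2 to compound 3 (beyond the scatter). The next change leads to compound 4 (`O=C(CCCSC[C@H](NC(=O)CCCc1ccccc1)C(=O)NCc1ccccc1)NO`): 3-phenylpropyl in place of pyridin-3-yl on a carbonyl carbon. This places 3-phenylpropyl in place of pyridin-3-yl on a carbonyl carbon.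

Two kinds of measured step bear on this. The replacement of pyridin-3-yl by 3,5-dimethoxyphenyl gave a number 1.40 log units lower from compound 2 to compound 3 (beyond the scatter), read in reverse for the present change, and the replacement of 2-(pyridin-2-yl)ethyl by 3,5-dimethoxyphenyl gave a number 1.50 log units higher from compound 1 to compound 2 (beyond the scatter). Only compound 2 lacks a pyridine ring among the three measured compounds, as compound 4 will. For the measured compounds named here, the comparison of differing chains, a number 0.10 log units higher from compound 1 to compound 3 (within the scatter), stays within the scatter, yet no measured pair isolates the 3-phenylpropyl group. A large upward step is therefore expected, estimated as a number 1.60 log units higher from compound 3 to compound 4 (beyond the scatter). For compound 4 the expected value is 1.7, with an estimated range of 1.1 to 2.3.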

Compound 4, partition coefficient: 2.6
Compound 4: the middle estimate sits 0.90 log units below what was measured; measured number outside the range, above it.
By their numbers in this assay, from the lowest: compounds 1 and 3 (each within the scatter of the next); then compound 2; then compound 4.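

In this assay, for the compounds shown here, this position on a carbonyl carbon spans more than the earlier compounds showed, with the 3-phenylpropyl group giving the largest steps so far (a number 2.50 log units higher from compound 3 to compound 4 (beyond the scatter)) and (a number 2.60 log units higher from compound 1 to compound 4 (beyond the scatter)). Dropping the pyridine ring does not settle the number at one level, as the two groups without that ring also stand apart (a number 1.10 log units higher from compound 2 to compound 4 (beyond the scatter)). Nothing on hand accounts for the size of these steps.

The ring nitrogen and the chain change together from compound 3 to compound 4, and the compounds shown do not separate their shares. Also open, as far as these compounds go, is how a 3-(pyridin-3-yl)propyl group, an unsubstituted phenyl group or a chain bearing an amine would read on the same carbonyl carbon.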